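Moving a Bromine Around a Pendant Phenyl Ring

A few compounds are considered here, and "the series" means these few. Any claim that something is new, unique, unknown or untested is made for them only; others in the source may bear on it.

Compound 1 `O=c1oc2ccccc2c2nc3c(ccc4cc[nH]c43)c(-c3cccc(Br)c3)c12` carries a 3-bromophenyl group on the shared core. In a functional assay on B16-F10 cells (Mus musculus) for cytotoxicity (on this read-out lower numbers stand for stronger inhibition and higher numbers for weaker inhibition), compound 1 gives 70700 nM, which is a weak effect. Compound 2 `O=c1oc2ccccc2c2nc3c(ccc4cc[nH]c43)c(-c3ccccn3)c12` carries a pyridin-2-yl group at the same place, and in this assay compound 2 gives 70700 nM. The step of no change at the digits printed from compound 1 to compound 2 (within the scatter) shows that exchanging the whole pendant ring for a different one left the read-out unmoved, so on the numbers shown compound 1 stands level with compound 2, and neither can be called the stronger of the two.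

Compound 3 `O=c1oc2ccccc2c2nc3c(ccc4cc[nH]c43)c(-c3ccccc3Br)c12` differs from compound 1 in a single respect: 2-bromophenyl in place of 3-bromophenyl on an aromatic carbon. The bromine stays, but sits at another position of the same pendant ring. Within the data shown here, no measured step shifts a bromine within a pendant ring, so the only guide is the step from compound 1 to compound 2, which stayed within the scatter even though the whole ring changed. The expected step of a 1.0-fold lower number from compound 1 to compound 3 (0.00 log units; within the scatter) is therefore none beyond the scatter, in either direction. In this assay compound 3 is estimated to give 70000 nM, with a likely range from 30000 nM to 160000 nM.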

Compound 3, half-maximal inhibitory concentration: 70700 nM
Compound 3: the middle estimate sits 1.0-fold (0.00 log units) below what was measured; the range from low to high includes it.
By their numbers in this assay, from the lowest: compounds 1, 2 and 3 (each within the scatter of the next).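

Shifting the bromine within the pendant ring gives no change at the digits printed from compound 1 to compound 3 (within the scatter) in this assay, so replacing 3-bromophenyl with 2-bromophenyl on this aromatic carbon of the shared core leaves the read-out where it was. The comparison of the two other groups gives no change at the digits printed from compound 2 to compound 3 (within the scatter), which means that 2-bromophenyl and pyridin-2-yl also stand level, and that neither moving the bromine nor exchanging the whole ring has separated these compounds at this place. Nothing measured here explains why these three compounds stand level.

As far as these compounds go, with only these three aromatic groups in view, it remains open whether any change at this place can shift the cytotoxic effect away from this weak level. An amine, a carboxylic acid or a longer alkyl chain in place of the pendant ring would test that question with groups quite unlike a bromophenyl or pyridinyl ring, and a real step in either direction would show whether this position matters at all.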